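The source may hold more compounds than are shown below. What is called first, only, known or untested is meant among the compounds shown, and "the series" means these compounds.

Three nucleosides have been read in a functional assay on HCT-116 cells (Homo sapiens), read by MTT assay, with a stated time of 72 h (a lower number here means a stronger inhibitor, a higher number a weaker inhibitor), and none of them gave a number. Compound 1 (`CSc1ncnc2c1c(-c1cccs1)cn2[C@@H]1O[C@H](CO)[C@@H](O)[C@H]1O`) gives > 20000 nM as a limit of the assay. Compound 2 (`Cc1nc(N)c2c(-c3ccoc3)cn([C@@H]3O[C@H](CO)[C@@H](O)[C@H]3O)c2n1`), which bears furan-3-yl, gives > 20000 nM as a limit too. Compound 3 (`Nc1nc2c(c(-c3ccco3)cn2[C@@H]2O[C@H](CO)[C@@H](O)[C@H]2O)c(=O)[nH]1`), which bears furan-2-yl, gives > 20000 nM as a limit again. Compound 3 thus stands at the limit of > 20000 nM in this assay, at which 3 of the 3 values shown sit, and has no number of its own.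

Compound 4 (`Nc1nc2c(c(-c3ccoc3)cn2[C@@H]2O[C@H](CO)[C@@H](O)[C@H]2O)c(=O)[nH]1`) has the same atoms as compound 3, joined differently: furan-3-yl in place of furan-2-yl on an aromatic carbon. Furan-3-yl takes the place of furan-2-yl on an aromatic carbon of the five-membered aromatic ring with 1 nitrogen. Among the compounds with values here, no measured pair isolates this swap, so no step beyond the scatter is expected in this assay and no direction is favoured. The estimated step of a number no higher from compound 3 to compound 4 (the limit leaves the size open) is expected to be no real change. Compound 4 is estimated at 20000 nM within an expected range of 8000 nM to 30000 nM and will most likely be reported only as a limit.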

Compound 4, half-maximal inhibitory concentration: 17600 nM
For compound 4 the middle estimate is 1.1-fold (0.06 log units) above the measured one, within the range that was stated.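

In this assay, within the data shown here, furan-3-yl in place of furan-2-yl on this aromatic carbon yields the only value shown that is a number and not a limit, with compound 4 at 17600 nM. As far as these compounds go, the change reads as an at least 1.1-fold lower number from compound 3 to compound 4 (0.05 log units; that floor lies within the scatter), and because compound 3 has only a limit, the true size of the step stays open and could be anywhere from that floor upward. Compound 4 is thus the one compound shown that registers within the range of this assay, while the others stay at the limit: the limit of > 20000 nM in this assay, at which 3 of the 4 values shown sit.

The compounds shown leave open whether a phenyl ring, an amine or a longer chain on this aromatic carbon would lower the number further. They also leave open whether the furan-3-yl result would hold with a different group on the rest of the shared core.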